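Methoxy for fluoro on the fused ring of compound 3

The compounds below may be only part of what the source reports. "The series", "measured", "known", "first", "only" and "open" are said of these compounds alone.

Measured so far:
compound 1, `Cc1ccc(-c2ccc(C)n2-c2ccc(-c3nc4ccc(F)cc4s3)cc2)cc1`: 3140 nM
compound 2, `Cc1ccc(-c2ccc(F)cc2)n1-c1ccc(-c2nc3ccc(F)cc3s2)cc1`: 3030 nM
compound 3, `Cc1ccc(-c2ccc([N+](=O)[O-])cc2)n1-c1ccc(-c2nc3ccc(F)cc3s2)cc1`: 1670 nM

In a functional assay on MDA-MB-231 cells (Homo sapiens) for cytotoxicity, read by sulforhodamine B assay, with a stated time of 48 h (a higher number here means a weaker inhibitor of growth, a lower number a stronger inhibitor of growth), compound 3 gives 1670 nM, the lowest of the three numbers, though its distance to both neighbours is within the scatter: a 1.8-fold lower number from compound 2 to compound 3 (0.26 log units; within the scatter) and a 1.9-fold lower number from compound 1 to compound 3 (0.27 log units; within the scatter). Between the other two, a 1.0-fold lower number from compound 1 to compound 2 (0.02 log units; within the scatter). All three measured steps therefore concern exchanges on one aromatic carbon of the outer aryl group, and none of them moved the number beyond the scatter.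

Compound 4, `COc1ccc2nc(-c3ccc(-n4c(C)ccc4-c4ccc([N+](=O)[O-])cc4)cc3)sc2c1`, differs from compound 3 at a different place: methoxy in place of fluoro on an aromatic carbon. For the measured compounds named here, no measured step touches this position, so the available steps only show that the series as a whole has so far been insensitive to single substituent exchanges. On that basis the expected change in this assay is none beyond the scatter, and the estimate for compound 4 is 1800 nM with a range of 600 nM to 5500 nM, which corresponds to an expected step of a 1.1-fold higher number from compound 3 to compound 4 (0.03 log units; within the scatter). The range is kept wide because the fused ring has not been varied among the measured compounds.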

Compound 4, concentration for 50% growth inhibition: 4560 nM
Compound 4: the middle estimate sits 2.5-fold (0.40 log units) below what was measured; low and high end bracket the measured number.
By their numbers in this assay, from the lowest: compounds 3, 2, 1 and 4 (each within the scatter of the next, the first and the last beyond it).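

Methoxy in place of fluoro on the fused ring is the first single exchange shown in this series to go beyond the scatter: in this assay the exchange gives a 2.7-fold higher number from compound 3 to compound 4 (0.44 log units; beyond the scatter) and so points towards a weaker inhibitor of growth. The earlier steps all lay on the outer aryl group and stayed within the scatter, which makes this aromatic carbon of the fused system the only place shown where a single exchange moves the number clearly, although the step is modest and rests on one pair of compounds. Nothing measured here accounts for this step.

Whether the change is particular to methoxy remains open: the compounds shown carry only fluoro or methoxy at this carbon, and a hydroxyl, a chlorine or an amine there would show how other groups compare with these two. For the compounds shown here, it is also open whether the same exchange would have a similar effect with the methyl group of compound 1 or the fluoro group of compound 2 on the outer aryl ring, as the step is seen only with the nitro group of compound 3.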